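One more chloro on the longer chain

The source may hold more compounds than are shown below. What is called first, only, known or untested is meant among the compounds shown, and "the series" means these compounds.

Compound 1 `CCCCCC(CCO)n1cnc2c(Cl)nc(Cl)nc21`: 6010 nM
Compound 2 `CCCCCCCCC(CCO)n1cnc2c(Cl)ncnc21`: 1370 nM

In a functional assay on SW480 cells (Homo sapiens) for antiproliferative activity, read by MTT assay, with a stated time of 48 h (on this read-out lower numbers stand for stronger inhibition and higher numbers for weaker inhibition), compound 2 gives 1370 nM as the lower of the two numbers, and its gap to compound 1 lies beyond the scatter. Those two compounds differ in more than one place, so neither value isolates a single change. Compound 3 `CCCCCCCCC(CCO)n1cnc2c(Cl)nc(Cl)nc21` has chloro in place of hydrogen on an aromatic carbon of compound 2, between two ring nitrogen atoms: chloro in place of hydrogen on an aromatic carbon. For the measured compounds named here, no measured pair shows this change alone, so no step beyond the scatter is expected in this assay. Compound 3 is expected at 1100 nM with an estimated range from 400 nM to 3000 nM as its span. This estimate means an expected 1.2-fold lower number from compound 2 to compound 3 (0.10 log units; within the scatter) overall.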

Compound 3, half-maximal inhibitory concentration: 24000 nM
For compound 3 the middle estimate is 22-fold (1.34 log units) below the measured one, and the stated range ends below it.
By their numbers in this assay, from the lowest: compound 2; then compound 1; then compound 3.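

In this assay, chloro in place of hydrogen on an aromatic carbon, between two ring nitrogen atoms, gives an 18-fold higher number from compound 2 to compound 3 (1.24 log units; beyond the scatter), so this position is sensitive to the change. With that chloro in place on both compounds, propyl in place of hydrogen on a saturated chain carbon gives a 4.0-fold higher number from compound 1 to compound 3 (0.60 log units; beyond the scatter), so the longer chain brings no gain here. Nothing available explains either step. The compounds shown leave open whether an amine or a methyl group at this position would give a number like that of chloro or hydrogen. They also leave open how a shorter chain would behave without this chloro.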